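Acetamido for methyl on the sulfonyl aryl of a bis-benzylidene piperidinone

The source may hold more compounds than are shown below. What is called first, only, known or untested is meant among the compounds shown, and "the series" means these compounds.

Measured compounds:
Compound 1 `O=C1/C(=C/c2ccccc2F)CN(S(=O)(=O)c2ccc(O[N+](=O)[O-])cc2)C/C1=C\c1ccccc1F`, with 6200 nM in a functional assay on SMMC-7721 cells (Homo sapiens) for cytotoxicity, read by MTT assay, with a stated time of 24 h; on this read-out lower numbers stand for stronger inhibition and higher numbers for weaker inhibition.
Compound 2 `Cc1ccc(S(=O)(=O)N2C/C(=C\c3cccc(F)c3)C(=O)/C(=C/c3cccc(F)c3)C2)cc1`, with 18100 nM in this assay.

Of the compounds shown here, two sharing the same core have been measured so far. In this assay compound 1 gives 6200 nM, and compound 2 gives 18100 nM. Compound 2 thus has the higher of the two numbers, and its gap to compound 1 lies beyond the usual scatter, so compound 2 is the weaker of the two on this read-out. The two differ in more than one place, so nothing more is drawn from their pair.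

Compound 3 `CC(=O)Nc1ccc(S(=O)(=O)N2C/C(=C\c3cccc(F)c3)C(=O)/C(=C/c3cccc(F)c3)C2)cc1` has not yet been measured. It differs from compound 2 in one place: acetamido in place of methyl on an aromatic carbon. Among the measured compounds shown here, no single-point step between measured compounds is available, so the size of this change can only be guessed. An expectation of a small step toward a lower number, not clearly beyond the scatter, is written as a 1.5-fold lower number from compound 2 to compound 3 (0.18 log units; within the scatter). Compound 3 is therefore expected to give about 12000 nM, with a plausible range from 4000 nM to 35000 nM.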

Compound 3, half-maximal inhibitory concentration: 10300 nM
For compound 3 the middle estimate is 1.2-fold (0.07 log units) above the measured one; measured number inside the range.
By their numbers in this assay, from the lowest: compounds 1, 3 and 2 (each within the scatter of the next, the first and the last beyond it).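

Among the compounds shown here, replacing methyl with acetamido on the aromatic carbon para to a large group gives the first single-place step: in this assay, the exchange amounts to a 1.8-fold lower number from compound 2 to compound 3 (0.24 log units; within the scatter). This position therefore carries a much larger group, one that brings a hydrogen-bond donor and a hydrogen-bond acceptor where methyl has neither, and the number stays within the usual scatter of repeated measurements. The compounds shown contain no independent measurement that could explain this result, so the step describes what happened but not why.

One step at one position cannot show how far this tolerance extends, and an amine, a carboxylic acid or a longer chain in the same place could read quite differently in this assay. For the compounds shown here, it also remains open whether the same exchange from 4-methylphenyl to 4-acetamidophenyl would give a similar step alongside the fluorophenyl groups of compound 1, since the comparison here rests only on the single pair that shares the fluorophenyl groups of compound 2.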